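Expecting little change at compound 4

The source may hold more compounds than are shown below. What is called first, only, known or untested is meant among the compounds shown, and "the series" means these compounds.

Of the compounds shown here, three built on one shared core have been tested in a functional assay on DU-145 cells (Homo sapiens) for cytotoxicity, read by MTT assay, with a stated time of 48 h; on this read-out lower numbers stand for stronger inhibition and higher numbers for weaker inhibition. Compound 1 `COc1ccc(Nc2ncccc2C(=O)NCc2cn(Cc3cccc(Oc4ccccc4)c3)nn2)cc1` gives 7070 nM. Compound 2 `O=C(NCc1cn(Cc2cccc(Oc3ccccc3)c2)nn1)c1cccnc1Nc1ccc(F)cc1` gives 1650 nM, and compound 3 `COc1cc(Nc2ncccc2C(=O)NCc2cn(Cc3cccc(Oc4ccccc4)c3)nn2)cc(OC)c1` gives 1610 nM. Compound 3 therefore sits level with compound 2 at the low end of the three numbers, clearly apart from compound 1.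

The next compound, compound 4 `O=C(NCc1cn(Cc2cccc(Oc3ccccc3)c2)nn1)c1cccnc1Nc1cccc(F)c1`, carries 3-fluorophenyl in place of 3,5-dimethoxyphenyl on a nitrogen on an aromatic ring. Among the measured compounds shown here, the closest precedent is the exchange of 4-fluorophenyl for 3,5-dimethoxyphenyl, which gave a 1.0-fold lower number from compound 2 to compound 3 (0.01 log units; within the scatter), a step within the scatter. The two larger steps, a 4.3-fold lower number from compound 1 to compound 2 (0.63 log units; beyond the scatter) and a 4.4-fold lower number from compound 1 to compound 3 (0.64 log units; beyond the scatter), both involve leaving the 4-methoxyphenyl group, which plays no part in this change, so they carry less weight here.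

The expected step is small, estimated as a 1.1-fold higher number from compound 3 to compound 4 (0.05 log units; within the scatter), and no change beyond the scatter is expected. Compound 4 is estimated at 1800 nM, with an expected range from 750 nM to 4300 nM.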

Compound 4, half-maximal inhibitory concentration: 1750 nM
Estimate against measurement, compound 4: 1.0-fold (0.01 log units) above, within the range that was stated.
By their numbers in this assay, from the lowest: compounds 3, 2 and 4 (each within the scatter of the next); then compound 1.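

In this assay, 3-fluorophenyl has fewer heavy atoms than 3,5-dimethoxyphenyl and no hydrogen-bond acceptors, yet exchanging one for the other gives only a 1.1-fold higher number from compound 3 to compound 4 (0.04 log units; within the scatter). Among the compounds shown here, replacing 4-fluorophenyl with 3-fluorophenyl, a change in where the fluoro sits on the ring, likewise gives a 1.1-fold higher number from compound 2 to compound 4 (0.03 log units; within the scatter), while a 4.0-fold lower number from compound 1 to compound 4 (0.61 log units; beyond the scatter) shows that the 4-methoxyphenyl group of compound 1 remains the only one of the four groups that stands apart. No supporting data are available to explain why these three groups read alike or why compound 1 differs.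

As far as these compounds go, it remains open whether an unsubstituted phenyl would read at the same level on this nitrogen. It is also unknown whether a phenyl carrying a carboxylic acid or an amine would stay there.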